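The compounds below may be only part of what the source reports. "The series", "measured", "known", "first", "only" and "open" are said of these compounds alone.

Measured so far in an ADME assay on CCRF-CEM cells (Homo sapiens) for cytotoxicity, with a stated time of 5 days; a lower number here means a stronger inhibitor, a higher number a weaker inhibitor:

- compound 1 `C=CCN(C)c1nc(N)nc2c1ncn2[C@H]1C[C@H](N=[N+]=[N-])[C@@H](CO)O1` gives 27000 nM
- compound 2 `[N-]=[N+]=N[C@H]1C[C@H](n2cnc3c(NCCCCCO)nc(N)nc32)O[C@@H]1CO` is recorded only as the limit > 100000 nM
- compound 3 `COc1nc(NC2CC2)c2ncn([C@H]3C[C@H](N=[N+]=[N-])[C@@H](CO)O3)c2n1` is likewise recorded only as the limit > 100000 nM

Compound 2 therefore stands at the weak end of what is shown, together with compound 3, on (the limit of > 100000 nM in this assay, at which 2 of the 3 values shown sit). For the measured compounds named here, the one step that reaches it is an at least 3.7-fold higher number from compound 1 to compound 2 (0.56 log units; beyond the scatter), so replacing the allyl(methyl)amino of compound 1 by the (5-hydroxypentyl)amino chain cost at least a modest amount.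

Compound 4 `C#CCNc1nc(N)nc2c1ncn2[C@H]1C[C@H](N=[N+]=[N-])[C@@H](CO)O1` is the next compound, and it differs from compound 2 by ethynyl in place of 4-hydroxybutyl on a saturated chain carbon bound to a nitrogen on an aromatic ring. Going by the values given here, this is the only measured step that bears on the change, and it runs the other way: the 5-hydroxypentyl chain leaves again, and what enters is propargylamino, a group with a triple bond outside aromatic rings rather than a hydroxyl, closer in size to the allyl(methyl)amino of compound 1. The step is therefore expected to lower the number, back towards where compound 1 sits, though compound 2 being a limit leaves the size uncertain. Compound 4 is estimated at 30000 nM, within 8000 nM to 100000 nM, which means an expected step of an at least 3.3-fold lower number from compound 2 to compound 4 (0.52 log units; beyond the scatter).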

Compound 4, half-maximal inhibitory concentration: > 100000 nM
Compound 4 ended at the assay's limit; the forecaster's own chance of this, stated with the estimate: 35%; middle value at least 3.3-fold (0.52 log units) away from the limit.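

In this assay compound 4 is recorded only as a limit, and it joins most of the compounds shown: the limit of > 100000 nM in this assay, at which 3 of the 4 values shown sit. Taking away the (5-hydroxypentyl)amino chain in favour of propargylamino did not return the number to the level of compound 1, although the step between compound 2 and compound 4 cannot be read, as both ends are limits. What is new is that propargylamino in place of allyl(methyl)amino on an aromatic carbon gives an at least 3.7-fold higher number from compound 1 to compound 4 (0.56 log units; beyond the scatter), so a chain without a hydroxyl can also end at the limit, and compound 1 alone keeps a measured value.

The compounds shown leave open whether the allyl group or the methyl on the nitrogen of compound 1 accounts for that measured value, as propargylamino differs from allyl(methyl)amino in both. An allylamino or a propargyl(methyl)amino group on the same carbon would separate the two.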